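This account rests on a few compounds, and the source may have more. Where it says the series, first, only, none or still open, it means among the compounds named here.

Both compounds measured so far were tested in a functional assay on KB cells (Homo sapiens) for antiproliferative activity; a lower number here means a stronger inhibitor, a higher number a weaker inhibitor:

- compound 1 `COc1ccc(C(c2ccc3cccnc3c2O)c2oc(CO)cc(=O)c2O)cc1`: < 0.3 ug/mL
- compound 2 `COc1ccc(C(c2ccc3cccnc3c2O)c2ccc3cccnc3c2O)cc1`: < 0.3 ug/mL

Compound 1 stands at < 0.3 ug/mL, which is a limit of the assay and not a number. Compound 2 stands at < 0.3 ug/mL, which is also a limit. The two compounds therefore share (the limit of < 0.3 ug/mL in this assay, at which 2 of the 2 values shown sit), and nothing can be said of any order between them.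

The next compound is compound 3 `CCOC(c1ccc(OC)cc1)c1ccc2cccnc2c1O`, which has not yet been measured. Its change from compound 1 is a group of 3 heavy atoms (2 carbon, 1 oxygen; no ring) in place of a group of 10 heavy atoms (6 carbon, 4 oxygen; one six-membered aromatic ring with 1 hetero atom), on a saturated chain carbon bound to two aromatic carbons: an ethoxy group takes the place of a much larger group with one six-membered aromatic ring, on a saturated chain carbon bound to two aromatic carbons.

Among the measured compounds shown here, no measured step shows what such a change does in this assay, so the expectation is a rough one. A move toward weaker inhibition is expected, of moderate but uncertain size, and it is estimated as an at least 3.3-fold higher number from compound 1 to compound 3 (0.52 log units; beyond the scatter). For compound 3 the expected value is 1 ug/mL, with an estimated range from 0.2 ug/mL to 6 ug/mL.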

Compound 3, half-maximal inhibitory concentration: 0.8 ug/mL
Compound 3: middle estimate off by 1.3-fold (0.10 log units), on the high side; the range from low to high includes it.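

In this assay, putting ethoxy in place of the much larger group with one six-membered aromatic ring, on a saturated chain carbon bound to two aromatic carbons, gives an at least 2.6-fold higher number from compound 1 to compound 3 (0.42 log units; beyond the scatter). Among the compounds shown here, this is the first readable step: compound 3 at 0.8 ug/mL carries a measured number, which shows that the group at this carbon affects the read-out and that the ethoxy compound still gives a value within the range of the assay. The step has only a lower bound and its full size stays unknown, because compound 1 rests on a limit and not on a number: the limit of < 0.3 ug/mL in this assay, at which 2 of the 3 values shown sit.

This single change removes a ring, hydrogen-bond donors and several acceptors at once, so the compounds shown do not tell which of these features accounts for the step, or whether size alone would do the same. As far as these compounds go, it also stays open whether a hydroxyl, an amine or a longer chain such as butoxy at this carbon would land nearer compound 3 or nearer the limit held by compound 1 and compound 2.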